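This account rests on a few compounds, and the source may have more. Where it says the series, first, only, none or still open, it means among the compounds named here.

In a functional assay on K562 cells (Homo sapiens) for antiproliferative activity, read by MTT assay, with a stated time of 72 h (on this read-out higher numbers stand for weaker inhibition and lower numbers for stronger inhibition), compound 1 (`CCOc1ccc(-c2ncnn2-c2cc(OC)c(OC)c(OC)c2)cc1`) gives 20 nM and compound 2 (`COc1cc(-n2ncnc2-c2ccc(SC)cc2)cc(OC)c1OC`) gives 340 nM, the higher of the two numbers. Compound 3 (`COc1cc(-n2ncnc2-c2ccc(F)cc2)cc(OC)c1OC`) differs from compound 2 by one change: fluoro in place of methylsulfanyl on an aromatic carbon, para to a large group. For the measured compounds named here, the only measured step at this place is a 17-fold higher number from compound 1 to compound 2 (1.23 log units; beyond the scatter). It is large, but it involves ethoxy and methylsulfanyl, not fluoro, so it sets no firm direction. Only a small shift towards a higher number is expected in this assay, an estimated 1.5-fold higher number from compound 2 to compound 3 (0.17 log units; within the scatter). For compound 3 the expected value is 500 nM, with an estimated range of 100 nM to 3000 nM.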

Compound 3, half-maximal inhibitory concentration: > 10000 nM
Compound 3 was reported as a limit (the forecaster's own chance of this, stated with the estimate: 10%); middle value at least 20-fold (1.30 log units) away from the limit.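

Compound 3 stands at a limit of the assay, not at a number: the limit of > 10000 nM in this assay, at which 1 of the 3 values shown sits. The position para to a large group is therefore more sensitive than one step could show, with fluoro in place of methylsulfanyl giving an at least 29-fold higher number from compound 2 to compound 3 (1.46 log units; beyond the scatter). Against ethoxy, the change gives an at least 500-fold higher number from compound 1 to compound 3 (2.69 log units; beyond the scatter), so all three groups are separated by steps beyond the scatter, in the order ethoxy, methylsulfanyl, fluoro.

On these data alone, the true size of both steps remains open, as compound 3 has only a limit. As far as these compounds go, whether a methoxy group, a longer propoxy chain or an amine at this position would hold the value of compound 1 also remains open.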